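This account rests on a few compounds, and the source may have more. Where it says the series, first, only, none or still open, it means among the compounds named here.

Measured compounds:
Compound 1, `O=C(C1COc2ccccc2O1)N1N=C(c2ccc(Br)cc2)CC1c1ccccc1F`: 8030 nM
Compound 2, `O=C(c1ccc2c(c1)OCCO2)N1N=C(c2ccccc2)CC1c1ccccc1F`: 2500 nM
Compound 3, `O=C(c1ccc2c(c1)OCCO2)N1N=C(c2ccc(Br)cc2)CC1c1ccccc1`: 1790 nM

All three were tested in a functional assay on WM 266-4 cells (Homo sapiens) for inhibition, read by MTT assay, with a stated time of 24 h; on this read-out higher numbers stand for weaker inhibition of growth and lower numbers for stronger inhibition of growth. Compound 2 stands second highest of the three numbers. Its nearest neighbour is compound 3, whose number lies within the scatter of that of compound 2, so the two cannot be ordered. Compound 1, the furthest, gives a number that lies beyond the scatter above compound 2, so compound 2 inhibits growth more strongly than compound 1 on this read-out. No two of the three measured compounds differ in only one place, so no single structural step can be read from them.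

Compound 4, `COc1ccc(C2CC(c3ccccc3)=NN2C(=O)c2ccc3c(c2)OCCO3)cc1`, has not yet been measured. It differs from compound 2 in one place: 4-methoxyphenyl in place of 2-fluorophenyl on a saturated ring carbon. Going by the values given here, no measured pair shows what such a change on the saturated ring carbon does here, so there is no basis for expecting a step in either direction beyond the scatter of this assay. Compound 4 is therefore expected to give about 2800 nM, with a likely range from 900 nM to 9000 nM. The step this estimate implies, a 1.1-fold higher number from compound 2 to compound 4 (0.05 log units; within the scatter), is expected to stay within the scatter.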

Compound 4, concentration for 50% growth inhibition: 8370 nM
Compound 4: the middle estimate sits 3.0-fold (0.48 log units) below what was measured; the measured number falls inside the stated range.
By their numbers in this assay, from the lowest: compounds 3 and 2 (each within the scatter of the next); then compounds 1 and 4 (each within the scatter of the next).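

Putting 4-methoxyphenyl in place of 2-fluorophenyl on the saturated ring carbon gives a 3.3-fold higher number from compound 2 to compound 4 (0.52 log units; beyond the scatter) in this assay, a modest step towards weaker inhibition of growth. Going by these compounds alone, this is the first single-place comparison in the set, and it shows that the group on this carbon is not interchangeable on the shared core: at least this one exchange moves the number beyond the scatter. No measurement shown here accounts for the step, so it remains an observation about this one pair and gives no explanation of how the position works.

The exchange alters the ring in two ways at once, losing the fluorine and gaining the methoxy group, so the compounds shown cannot separate the two contributions, and 4-fluorophenyl or 2-methoxyphenyl on this carbon would be needed to tell them apart. As far as these compounds go, it also remains open how groups of a different kind behave here, such as a 4-aminophenyl or a 4-carboxyphenyl ring, and whether this step would hold on a core carrying 4-bromophenyl instead of phenyl.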